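The source may report more compounds than this note shows. Statements on the series, on what has been measured and on what is new or still open speak of the compounds shown alone.

Going by the values given here, in a functional assay on MDA-MB-231 cells (Homo sapiens) for antiproliferative activity, read by MTT assay, with a stated time of 48 h (a lower number here means a stronger inhibitor, a higher number a weaker inhibitor), compound 1 `C=CS(=O)(=O)N1CCN(c2ncnc3sc(-c4ccccc4)cc23)CC1` gives 54200 nM, the higher of the two numbers measured so far, while compound 2 `C=CS(=O)(=O)N1CCN(c2ncnc3sc(-c4ccc(C(F)(F)F)cc4)cc23)CC1` gives 6410 nM. Among the compounds with values here, the single measured step, an 8.5-fold lower number from compound 1 to compound 2 (0.93 log units; beyond the scatter), comes from trifluoromethyl in place of hydrogen on an aromatic carbon. Compound 3 `C=CS(=O)(=O)N1CCN(c2ncnc3sc(-c4cccc5ncccc45)cc23)CC1` has not yet been measured. Its change from the parent is quinolin-5-yl in place of phenyl on an aromatic carbon, next to the ring sulfur: quinolin-5-yl in place of phenyl on an aromatic carbon. Within the data shown here, only the step to compound 2 bears on this, and only indirectly, since that step adds a group to the phenyl rather than replacing the phenyl. A lower number in the same direction, but of smaller size and with wide uncertainty, is therefore expected. The estimated change is a 3.0-fold lower number from compound 1 to compound 3 (0.48 log units; beyond the scatter). For compound 3 the estimated value is 18000 nM, with an expected range of 4000 nM to 60000 nM.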

Compound 3, half-maximal inhibitory concentration: 21000 nM
Compound 3: middle estimate off by 1.2-fold (0.07 log units), on the low side, within the range that was stated.
By their numbers in this assay, from the lowest: compound 2; then compound 3; then compound 1.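

In this assay, the aromatic carbon next to the ring sulfur accepts outright replacement of the phenyl as well as substitution on it, since quinolin-5-yl gives a 2.6-fold lower number from compound 1 to compound 3 (0.41 log units; beyond the scatter). The change from the 4-(trifluoromethyl)phenyl group to quinolin-5-yl gives a 3.3-fold higher number from compound 2 to compound 3 (0.52 log units; beyond the scatter), so at this position the quinolin-5-yl group falls short of the 4-(trifluoromethyl)phenyl group, although it still improves on the unsubstituted phenyl. The entering group adds both a second six-membered aromatic ring and a ring nitrogen, and these three compounds cannot tell the two additions apart. No evidence is available on what lies behind either step. On these data alone, it remains open how a naphthyl group, which keeps the second ring without the nitrogen, or a phenyl carrying an amine or a carboxylic acid, would compare.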